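Replacing (benzyloxy)methyl by hydroxy in an inactive series

The compounds below may be only part of what the source reports. "The series", "measured", "known", "first", "only" and "open" are said of these compounds alone.

Compound 2 `O=c1cc(CC(COCc2ccccc2)COCc2ccccc2)[nH]c(=O)[nH]1` was tested in a functional assay on MCF7 cells (Homo sapiens) for antiproliferative activity, read by MTT assay, with a stated time of 72 h; a lower number here means a stronger inhibitor, a higher number a weaker inhibitor. In this assay compound 2 gives > 100000 nM, which is a limit of the assay and not a number. Compound 1 `O=c1cc(CC(O)(COCc2ccccc2)COCc2ccccc2)[nH]c(=O)[nH]1` in this assay likewise gives only a limit, > 100000 nM. Compound 3 `COCn1c(CC(COCc2ccccc2)COCc2ccccc2)cc(=O)[nH]c1=O` in this assay gives > 100000 nM, again a limit. Each of the three values therefore sits at the limit of > 100000 nM in this assay, at which 3 of the 3 values shown sit. The step that the two limits leave unreadable from compound 1 to compound 2 and the step that the two limits leave unreadable from compound 2 to compound 3 thus give no readable size. Compound 4 `O=c1cc(CC(O)COCc2ccccc2)[nH]c(=O)[nH]1` differs from compound 2 by hydroxy in place of (benzyloxy)methyl on a saturated chain carbon bound to two saturated chain carbons. Among the measured compounds shown here, no measured step bears on this change directly, and the two that are known, one involving a hydroxy and one a methoxymethyl, were both left unreadable by the limits, so no size of step can be drawn from them. With all three values at the limit, compound 4 is expected to remain near it. The step of a number no higher from compound 2 to compound 4 (the limit leaves the size open) is estimated to be small. Compound 4 is therefore expected to give about 100000 nM, within 30000 nM to 300000 nM, and most likely to be reported again only as a limit.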

Compound 4, half-maximal inhibitory concentration: > 100000 nM
Compound 4 was reported as a limit; the forecaster's own chance of this, stated with the estimate: 85%; the middle value lies on the limit itself.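

Compound 4, like compounds 1, 2 and 3, stands only as a limit, so neither its step from compound 2 nor its step from compound 1 can be read: the limit of > 100000 nM in this assay, at which 4 of the 4 values shown sit.

The compounds shown leave open whether any of these changes alters activity in this assay at all.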